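Methylating the Ring Amine: Expected Loss of Maximal Response

The source may hold more compounds than are shown below. What is called first, only, known or untested is meant among the compounds shown, and "the series" means these compounds.

Measured compounds:
compound 1 `CN1C[C@H]2C=C(c3cccnc3)C[C@H](C2)C1` gives 19%
compound 2 `Clc1ccc(C2=CC3CNCC(C2)C3)cn1` gives 98%
compound 3 `Fc1ccc(C2=CC3CNCC(C2)C3)cn1` gives 104%

In an in vitro functional assay on SH-EP1 cells for agonist activity at Neuronal acetylcholine receptor; alpha4/beta2 (Homo sapiens), read by FLIPR and calcium flux (a lower number here means a smaller maximal response, a higher number a larger maximal response), compound 3 stands at the top of the three numbers; compound 2 sits within the scatter of it, while compound 1 lies far lower. Compound 4 `CN1CC2C=C(c3ccc(F)nc3)CC(C2)C1` differs from compound 3 by methyl in place of hydrogen on an amine nitrogen in a ring. Going by the values given here, the only measured step, a number 6 percentage points higher from compound 2 to compound 3 (within the scatter), concerns the pyridine substituent and is within the scatter, so it says nothing about the amine. Among the compounds with values here, no measured pair isolates the methyl change: compound 1, which carries the methyl, differs from compound 3 in two places. Compound 3 gives 104%, and compound 1 gives 19%; that is all the data show. For compound 4 a large drop is therefore expected, a number 74 percentage points lower from compound 3 to compound 4 (beyond the scatter), giving an estimated 30% with a range of 10% to 70%.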

Compound 4, largest response reached (reported as percent of maximum), in percent of the reference or control that the assay uses: 22%
Estimate against measurement, compound 4: 8 percentage points above; the range from low to high includes it.
By their numbers in this assay, from the lowest: compounds 1 and 4 (each within the scatter of the next); then compounds 2 and 3 (each within the scatter of the next).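

In this assay there is now a pair that differs in one place only: methyl in place of hydrogen on the amine nitrogen in a ring gives a number 82 percentage points lower from compound 3 to compound 4 (beyond the scatter) on its own. The loss of maximal response can therefore be assigned to this single methyl, at least in the compound carrying the fluoro substituent, rather than to several differences at once. Nothing measured here explains why this small change has such a large effect.

On these data alone, whether ethyl or a longer chain on the same nitrogen lowers the response as far remains open. So does whether the methyl has the same effect when chloro replaces fluoro on the pyridine.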